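Compound 3: swapping benzyloxy on a limit-bound series

The compounds below may be only part of what the source reports. "The series", "measured", "known", "first", "only" and "open" are said of these compounds alone.

In an ADME assay on Akata cells (Homo sapiens) for cytotoxicity, with a stated time of 7 days (a higher number here means that more compound is tolerated, a lower number that less compound is tolerated), compound 2 `Nc1nc(OCc2ccccc2)c2ncn(/C=C3/CC3(CO)CO)c2n1` gives > 20000 nM, which is a limit and not a number. Compound 1 `CN(C)c1nc(N)nc2c1ncn2/C=C1/CC1(CO)CO` gives > 24000 nM, which is also a limit. Compound 2 therefore has no exact standing in this assay.

Compound 3 `Nc1nc(N2CCCC2)c2ncn(/C=C3/CC3(CO)CO)c2n1` carries pyrrolidin-1-yl in place of benzyloxy on an aromatic carbon.

For the measured compounds named here, only one measured step bears on this change, since it also exchanges the benzyloxy group: a step that the two limits leave unreadable from compound 1 to compound 2. That step has no readable size, so it gives no ground for expecting a shift in either direction. The expected step, with none foreseen beyond the scatter, is a step that the limit leaves unreadable from compound 2 to compound 3. A further limit is the likeliest report. The estimate for compound 3 is 22000 nM, with an expected range of 10000 nM to 45000 nM.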

Compound 3, half-maximal cytotoxic concentration: > 24000 nM
Compound 3 was reported as a limit (the forecaster's own chance of this, stated with the estimate: 75%); middle value at least 1.0-fold (0.03 log units) from the limit.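

For the compounds shown here, compound 1, compound 2 and compound 3 are all reported as limits and not as numbers in this assay and no step among them can be read. The compounds shown leave open whether the benzyloxy, dimethylamino and pyrrolidin-1-yl groups differ at all in this read-out.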